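The compounds below may be only part of what the source reports. "The series", "measured", "known", "first", "only" and "open" are said of these compounds alone.

Compound 2 `Cc1nc2cc(C(=O)NCCC(C)C)nn2c(-c2cc(F)c3c(c2C)CCCO3)c1[C@H](OC(C)(C)C)C(=O)O` is the reference for this step. In an ADME assay on MT2 cells (Homo sapiens) for cytotoxicity (a higher number here means that more compound is tolerated, a lower number that less compound is tolerated), compound 2 gives > 40000 nM, which is a limit of the assay and not a number. Compound 1 `COc1cc(CNC(=O)c2cc3nc(C)c([C@H](OC(C)(C)C)C(=O)O)c(-c4cc(F)c5c(c4C)CCCO5)n3n2)ccc1F` carries 4-fluoro-3-methoxyphenyl where compound 2 carries isobutyl. In this assay compound 1 gives > 20000 nM, likewise a limit rather than a number. The step that the two limits leave unreadable from compound 1 to compound 2 is therefore not readable, since the two values sit at the limit of > 20000 nM in this assay, at which 1 of the 2 values shown sits, and at the limit of > 40000 nM in this assay, at which 1 of the 2 values shown sits. Compound 3 `Cc1nc2cc(C(=O)NCC3CCOCC3)nn2c(-c2cc(F)c3c(c2C)CCCO3)c1[C@H](OC(C)(C)C)C(=O)O` is not yet measured. It differs from compound 2 by oxan-4-yl in place of isobutyl on a saturated chain carbon bound to an amide-type nitrogen. Among the compounds with values here, no measured step reads cleanly, so no direction can be drawn from it; the one comparable change, from compound 1 to compound 2, left the assay at a limit in each case. For compound 3 the expected step of a number no higher from compound 2 to compound 3 (the limit leaves the size open) is none beyond the scatter. Compound 3 is estimated at 40000 nM, with a range of 20000 nM to 80000 nM, and most likely the assay again reports only a limit.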

Compound 3, half-maximal cytotoxic concentration: > 40000 nM
Compound 3: no number, only a limit; the forecaster's own chance of this, stated with the estimate: 85%; the middle value lies on the limit itself.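

In this assay compound 3 gives > 40000 nM, a limit and not a number. The steps to compound 3 from compound 1 and compound 2 cannot be read. Open remains whether the amide substituents of these three compounds differ at all in this assay.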